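The source may hold more compounds than are shown below. What is called first, only, known or untested is meant among the compounds shown, and "the series" means these compounds.

In a functional assay (aorta) with Oryctolagus cuniculus as the target (on this read-out higher numbers stand for weaker binding and lower numbers for tighter binding), three compounds sharing one core have been measured. Compound 1 `CC(=O)c1ccc(OCCCN2CCC(C(c3ccc(F)cc3)c3ccc(F)cc3)CC2)cc1` gives 2.51 nM, compound 2 `N#Cc1ccc(OCCCN2CCC(C(c3ccc(F)cc3)c3ccc(F)cc3)CC2)cc1` gives 5.01 nM and compound 3 `CN(CCCN1CCC(C(c2ccc(F)cc2)c2ccc(F)cc2)CC1)c1ccccc1` gives 2 nM. Compound 3 belongs to the low end of these numbers, as two steps show: a 1.3-fold lower number from compound 1 to compound 3 (0.10 log units; within the scatter), and a 2.5-fold lower number from compound 2 to compound 3 (0.40 log units; beyond the scatter).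

Compound 4 `Fc1ccc(C(c2ccc(F)cc2)C2CCN(CCCSc3ccccc3)CC2)cc1` has not yet been measured. It carries phenylsulfanyl in place of methyl(phenyl)amino on a saturated chain carbon, three bonds along the chain from an amine nitrogen in a ring. Going by the values given here, no measured step makes this exact exchange. The two steps into compound 3 replace a group at the same place, and the larger of them is still modest. The remaining step, a 2.0-fold higher number from compound 1 to compound 2 (0.30 log units; within the scatter), is also small. On this limited evidence, no step beyond the scatter is expected in this assay, and no direction can be firmly assigned. The expected change is a 1.5-fold higher number from compound 3 to compound 4 (0.18 log units; within the scatter). For compound 4 the estimated value is 3 nM, with an expected range of 1 nM to 9 nM.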

Compound 4, dissociation constant: 3.16 nM
The estimate for compound 4 lay 1.1-fold (0.02 log units) below the measured number; low and high end bracket the measured number.
By their numbers in this assay, from the lowest: compounds 3, 1, 4 and 2 (each within the scatter of the next, the first and the last beyond it).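

Replacing methyl(phenyl)amino with phenylsulfanyl on a saturated chain carbon, three bonds along the chain from an amine nitrogen in a ring, gives a 1.6-fold higher number from compound 3 to compound 4 (0.20 log units; within the scatter) in this assay, so this position accepts sulfur where compound 3 carries nitrogen without a change beyond the scatter. The steps of a 1.6-fold lower number from compound 2 to compound 4 (0.20 log units; within the scatter) and a 1.3-fold higher number from compound 1 to compound 4 (0.10 log units; within the scatter) are also within the scatter, so phenylsulfanyl cannot be told apart from 4-cyanophenoxy or 4-acetylphenoxy here, even though compound 3 and compound 2 differ beyond it. No measurement offered here accounts for how closely these groups read.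

Unsubstituted phenoxy would set oxygen directly against sulfur and nitrogen at this place, and that comparison remains open. Also open, going by these compounds, is whether a carboxylic acid, a group with no aromatic ring, or a longer chain would stay in the same range in this assay as well.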